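Compound 2 to compound 3: sulfur chain change

The source may hold more compounds than are shown below. What is called first, only, known or untested is meant among the compounds shown, and "the series" means these compounds.

For the measured compounds named here, in a functional assay on HT cells (Homo sapiens) for antiproliferative activity, read by fluorescence, with a stated time of 72 h (on this read-out lower numbers stand for stronger inhibition of growth and higher numbers for weaker inhibition of growth), compound 1 (`CC(C)c1n[nH]c2c(NCc3ccc(-c4ccccn4)cc3)nc(SC(C)C(C)O)nc12`) gives 190 nM and compound 2 (`CC(C)c1n[nH]c2c(NCc3ccc(-c4ccccn4)cc3)nc(SC[C@H](O)CN)nc12`) gives 63 nM, the lower of the two numbers so far. Compound 3 (`CNCCSc1nc(NCc2ccc(-c3ccccn3)cc2)c2[nH]nc(C(C)C)c2n1`) has 2-(methylamino)ethyl in place of 3-amino-2-hydroxypropyl on the sulfur: (methylamino)methyl in place of 2-amino-1-hydroxyethyl on a saturated chain carbon bound to a sulfur. Going by the values given here, one measured step bears on this, also a change of the chain on the sulfur: a 3.0-fold lower number from compound 1 to compound 2 (0.48 log units; beyond the scatter), a modest step. That step does not remove the hydroxy group while keeping the amine, so the data do not isolate the present change. Given the modest size of that one step, no clear shift in either direction is expected, and the estimated change is a 1.2-fold higher number from compound 2 to compound 3 (0.08 log units; within the scatter), which would stay within the scatter. For compound 3 the estimate is 75 nM, with an expected range from 28 nM to 200 nM in this assay.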

Compound 3, concentration for 50% growth inhibition: 56 nM
Compound 3: middle estimate off by 1.3-fold (0.13 log units), on the high side; the range from low to high includes it.
By their numbers in this assay, from the lowest: compounds 3 and 2 (each within the scatter of the next); then compound 1.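

In this assay, the step is a 1.1-fold lower number from compound 2 to compound 3 (0.05 log units; within the scatter), so the 2-(methylamino)ethyl chain on the sulfur cannot be told apart from the 3-amino-2-hydroxypropyl chain, even though the hydroxy group and the defined stereocentre are gone. The second step, a 3.4-fold lower number from compound 1 to compound 3 (0.53 log units; beyond the scatter), shows that a chain with an amine but no hydroxy group also gives a lower number than the 2-hydroxy-1-methylpropyl chain, so among these three compounds, both chains bearing an amine lie below the one without. No measurement at hand explains these numbers.

The compounds shown leave open whether the amine itself accounts for the gap to compound 1, whose chain also differs in its branching. A straight 2-hydroxyethyl chain, a carboxylic acid, a dimethylamino group or a longer amine chain on the sulfur would test this.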